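The source may report more compounds than this note shows. Statements on the series, on what has been measured and on what is new or still open speak of the compounds shown alone.

Compound 1 `COc1ccc2nc(C)cc(NCC(=O)Nc3cc(C)cc(C)c3)c2c1`: 6310 nM
Compound 2 `COc1ccc2nc(C)cc(OCC(=O)Nc3cccc(C)c3)c2c1`: 39800 nM

In a toxicity assay on HepG2 cells (Homo sapiens) for inhibition, read by CellTiter-Glo, with a stated time of 48 h (on this read-out higher numbers stand for weaker inhibition and lower numbers for stronger inhibition), compound 2 gives the higher of the two numbers; compound 1 stands a good deal lower, and the two values differ beyond the usual scatter. Compound 3 `COc1ccc2nc(C)cc(OCC(=O)Nc3c(C)cncc3C)c2c1` follows from compound 2 by one change: 3,5-dimethylpyridin-4-yl in place of 3-methylphenyl on an amide-type nitrogen. For the measured compounds named here, no measured pair in this set mirrors that exchange, so no step size can be drawn from the data. The step from compound 2 to compound 3 in this assay is expected to be small, a 1.0-fold higher number from compound 2 to compound 3 (0.00 log units; within the scatter), probably within the scatter and with no firm direction. Compound 3 is therefore estimated at 40000 nM, with a likely range of 15000 nM to 100000 nM.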

Compound 3, half-maximal inhibitory concentration: 12600 nM
Beside the measured number, compound 3's estimate is 3.2-fold (0.50 log units) above it; measured number below the stated range.
By their numbers in this assay, from the lowest: compounds 1 and 3 (each within the scatter of the next); then compound 2.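

In this assay the group on the amide-type nitrogen proves able to shift the number: 3,5-dimethylpyridin-4-yl in place of 3-methylphenyl gives a 3.2-fold lower number from compound 2 to compound 3 (0.50 log units; beyond the scatter) and so points towards stronger inhibition. For the compounds shown here, the earlier compounds held no pair differing in one place, so this is the first reading of a change at this position. Nothing measured here explains the step. From the compounds shown here alone, whether it belongs to the ring nitrogen or to the added methyl stays open. So does how an unsubstituted pyridin-4-yl, or a phenyl bearing a carboxylic acid, would read at this position.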